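The compounds below may be only part of what the source reports. "The series", "measured", "known", "first", "only" and "open" are said of these compounds alone.

Compound 1 `CSc1ccc(OC(C)(C)C2OCC(C/C=C\CCC(=O)O)C(c3cccnc3)O2)c([N+](=O)[O-])c1` gives 22 nM in an assay for inhibition of Thromboxane-A synthase (Homo sapiens), using microsomes; a higher number here means a weaker inhibitor, a lower number a stronger inhibitor. Compound 2 `CC(C)(Oc1ccccc1O)C1OCC(C/C=C\CCC(=O)O)C(c2cccnc2)O1` gives 32 nM in this assay, and compound 3 `COc1ccc(OC(C)(C)C2OCC(C/C=C\CCC(=O)O)C(c3cccnc3)O2)c([N+](=O)[O-])c1` gives 37 nM in this assay. Compound 2 stands second highest of these three numbers, though both neighbours lie within the scatter of it. Compound 4 `CC(C)(Cc1ccc(F)cc1C#N)C1OCC(C/C=C\CCC(=O)O)C(c2cccnc2)O1` differs from compound 2 in one place: a group of 10 heavy atoms (8 carbon, 1 nitrogen, 1 fluorine; one six-membered aromatic ring of carbon only) in place of a group of 8 heavy atoms (6 carbon, 2 oxygen; one six-membered aromatic ring of carbon only), on a saturated chain carbon bound to two saturated chain carbons and a saturated ring carbon. The two measured steps at that same place, a 1.5-fold higher number from compound 1 to compound 2 (0.16 log units; within the scatter) and a 1.2-fold higher number from compound 2 to compound 3 (0.06 log units; within the scatter), both stayed within the scatter, so exchanging the group on that saturated chain carbon has so far moved the numbers little. Within the data shown here, the group entering compound 4 has no measured precedent, so little beyond the scatter is expected. Compound 4 is therefore expected at about 40 nM, between 15 nM and 120 nM. The expected step is a 1.3-fold higher number from compound 2 to compound 4 (0.10 log units; within the scatter).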

Compound 4, half-maximal inhibitory concentration: < 10 nM
Compound 4: no number, only a limit; the forecaster's own chance of this, stated with the estimate: 3%; at least 4.0-fold (0.60 log units) between middle value and limit.
By their numbers in this assay, from the lowest: compounds 1, 2 and 3 (each within the scatter of the next). At a limit, below all of these: compound 4.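

Exchanging the group on this saturated chain carbon now moves the number beyond the scatter, with an at least 3.2-fold lower number from compound 2 to compound 4 (0.50 log units; beyond the scatter). The place is therefore less indifferent to what sits on it than compounds 1, 2 and 3 alone suggested. Compound 4 gives a limit of the assay and not a number: the limit of < 10 nM in this assay, at which 1 of the 4 values shown sits.

The entering group differs from 2-hydroxyphenoxy in several features at once, including its nitrile, its fluorine and the loss of the hydrogen-bond donor, so the compounds shown do not tell which feature goes with the step. Going by these compounds, how an amine or a longer chain on that carbon would compare also stays open.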